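A few compounds are considered here, and "the series" means these few. Any claim that something is new, unique, unknown or untested is made for them only; others in the source may bear on it.

Compound 1 `O[C@@H]1[C@H](O)CS[C@H]1Cn1cnc2c(NCc3cccc(Br)c3)nc(Cl)nc21`: 21%
Compound 2 `O[C@@H]1[C@H](O)CS[C@H]1Cn1cnc2c(NCc3cccc(I)c3)nc(Cl)nc21`: 10%

In an assay on CHO cells for displacement of a labelled ligand from adenosine receptor A3 (Homo sapiens), with a stated time of 60 min, tested at 10 uM (a higher number here means more inhibition at the concentration tested (going by the name of the read-out), a lower number less inhibition), compound 2 gives 10%, the lower of the two measured numbers; compound 1 gives 21%, and the step of a number 11 percentage points lower from compound 1 to compound 2 (beyond the scatter) lies beyond the scatter. Compound 3 `O[C@@H]1[C@H](O)CS[C@H]1Cn1cnc2c(NCc3cccc(F)c3)nc(Cl)nc21` differs from compound 2 by fluoro in place of iodo on an aromatic carbon, a change confined to that one aromatic carbon. Among the measured compounds shown here, only one measured step bears on it: the exchange of one halogen for another at the same place, which gave a number 11 percentage points lower from compound 1 to compound 2 (beyond the scatter), a modest fall. That single step does not show whether a further halogen swap at this carbon would move the number up, down or not at all; it only shows that such a swap can move it beyond the scatter. The expectation is that compound 3 returns a step of about a number 10 percentage points higher from compound 2 to compound 3 (within the scatter) in this assay, with appreciable uncertainty in either direction. Compound 3 is therefore estimated at 20%, in a range from 5% to 40%.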

Compound 3, a percentage reported as inhibition, at one concentration (the size of the read-out at that concentration, not a potency): 17.6%
Estimate against measurement, compound 3: 2.4 percentage points above; the measured number falls inside the stated range.
By their numbers in this assay, from the lowest: compounds 2, 3 and 1 (each within the scatter of the next, the first and the last beyond it).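

In this assay the exchange of iodo for fluoro at this aromatic carbon gives a number 7.6 percentage points higher from compound 2 to compound 3 (within the scatter) and the exchange of bromo for fluoro gives a number 3.4 percentage points lower from compound 1 to compound 3 (within the scatter) so compound 3 cannot be told apart from either of the other two. Only a number 11 percentage points lower from compound 1 to compound 2 (beyond the scatter) remains beyond the scatter, and the three halogens therefore form no clear order at this place. Nothing available here accounts for these numbers.

On these data alone, it remains open whether a chloro group at the same aromatic carbon would fit with these three halogens, and whether a group of another kind there, such as an amine, a methoxy group or a nitrile, would move the number beyond the scatter. As far as these compounds go, the effect of a halogen on the other carbons of this ring also remains open.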